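Aryl hydrazone ureas on a shared diaryl ether core

The source may report more compounds than this note shows. Statements on the series, on what has been measured and on what is new or still open speak of the compounds shown alone.

Measured compounds:
compound 1, `CN(C)CCn1cnnc1-c1cc(Oc2ccc(NC(=O)N/N=C/c3cc(C(C)(C)C)cc(C(C)(C)C)c3O)cc2F)ccn1`: 980 nM
compound 2, `CN(C)CCn1cnnc1-c1cc(Oc2ccc(NC(=O)N/N=C/c3ccccc3O[N+](=O)[O-])cc2F)ccn1`: 1200 nM
compound 3, `Cn1ncnc1-c1cc(Oc2ccc(NC(=O)N/N=C/c3ccccc3)cc2F)ccn1`: > 100000 nM (a limit)

In a functional assay on A549 cells (Homo sapiens) for cytotoxicity, read by MTT assay, with a stated time of 72 h (a lower number here means a stronger inhibitor, a higher number a weaker inhibitor), compound 2 gives 1200 nM and compound 1 gives 980 nM; the two lie within the scatter of each other. Among the measured compounds shown here, for compound 3 the reading in this assay is a limit, > 100000 nM, and it is the only such value here (the limit of > 100000 nM in this assay, at which 1 of the 3 values shown sits). Compound 4, `CN(C)CCn1cnnc1-c1cc(Oc2ccc(NC(=O)N/N=C/c3cccc(Br)c3)cc2F)ccn1`, differs from compound 2 by 3-bromophenyl in place of 2-(nitrooxy)phenyl on a carbon with a double bond to nitrogen. For the measured compounds named here, no step between two measured compounds of this set is available in this assay, so the size of the change is not anchored. The step of a 2.5-fold higher number from compound 2 to compound 4 (0.40 log units; beyond the scatter) is expected to be a modest weakening, somewhat beyond the scatter. Compound 4 is estimated at 3000 nM, with a range from 800 nM to 20000 nM.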

Compound 4, half-maximal inhibitory concentration: 970 nM
Compound 4: the middle estimate sits 3.1-fold (0.49 log units) above what was measured; low and high end bracket the measured number.
By their numbers in this assay, from the lowest: compounds 4, 1 and 2 (each within the scatter of the next). At a limit, above all of these: compound 3.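

In this assay this place tolerates a change of aryl group: a 1.2-fold lower number from compound 2 to compound 4 (0.09 log units; within the scatter), so 3-bromophenyl and 2-(nitrooxy)phenyl are not told apart here. Compound 4 carries no nitrooxy group, so that group is not required for a reading at this level on the shared core. Nothing measured here speaks to a cause for this step.

Open, from the compounds shown here alone, is whether a carboxylic acid or an amine on the phenyl ring at this place would hold the reading. Also open, going by these compounds, is how a plain phenyl group would read on the core of compound 2.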